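This account rests on a few compounds, and the source may have more. Where it says the series, first, only, none or still open, it means among the compounds named here.

Compound 1 `N=C(N)NCCC[C@H](NC(=O)[C@@H]1CCCN1C(=O)[C@@H](NC(=O)OCc1ccccc1)C1CCCCC1)C(=O)CF` and compound 2 `CC(C)[C@H](NC(=O)OCc1ccccc1)C(=O)N[C@@H](CO)C(=O)N[C@@H](CCCNC(=N)N)C(=O)CF` are built on different cores; the difference between the two cores is not broken down here. In a functional assay on OCI-Ly3 cells (Homo sapiens) for inhibition, read by CellTiter-Glo, with stated times of 48 h and 96 h (on this read-out higher numbers stand for weaker inhibition of growth and lower numbers for stronger inhibition of growth), compound 1 gives 1450 nM, the highest number among the three measured, while compound 2 gives 290 nM. Compound 3 `CC(C)[C@H](NC(=O)c1ccc(Br)cc1)C(=O)N[C@@H](CO)C(=O)N[C@@H](CCCNC(=N)N)C(=O)CF` carries the change 4-bromophenyl in place of benzyloxy on a carbonyl carbon relative to compound 2, and in this assay compound 3 gives 150 nM; the step is a 1.9-fold lower number from compound 2 to compound 3 (0.29 log units; within the scatter). Compound 4 `N=C(N)NCCC[C@H](NC(=O)[C@@H]1CCCN1C(=O)[C@@H](NC(=O)c1ccc(Br)cc1)C1CCCCC1)C(=O)CF` is the unmeasured partner of compound 1 with the same change, (4-bromophenyl in place of benzyloxy on a carbonyl carbon), made at the same place as in the measured pair. Going by the values given here, the single observation of this change is a 1.9-fold lower number from compound 2 to compound 3 (0.29 log units; within the scatter), a step within the scatter. On that basis a step of similar size is expected, a 1.9-fold lower number from compound 1 to compound 4 (0.29 log units; within the scatter). In this assay compound 4 is estimated at 750 nM, with a range from 350 nM to 1600 nM.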

Compound 4, concentration for 50% growth inhibition: 130 nM
The estimate for compound 4 lay 5.8-fold (0.76 log units) above the measured number, and the stated range ends above it.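

In this assay, 4-bromophenyl in place of benzyloxy on a carbonyl carbon gives an 11-fold lower number from compound 1 to compound 4 (1.05 log units; beyond the scatter), and the size of the step does not carry from one core to the other: the same change on two cores in this assay, a 1.9-fold lower number (0.29 log units; within the scatter) from compound 2 to compound 3 and an 11-fold lower number (1.05 log units; beyond the scatter) from compound 1 to compound 4, 5.8-fold (0.76 log units) apart, beyond the scatter of two such steps. Going by these compounds alone, both steps run toward a lower number, but only the step on the core of compound 1 lies beyond the scatter, so a step read on one core is a poor guide to its size on the other. With a single pair on each core, these data do not show which part of the cores sets the gap.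

Still open, from the compounds shown here alone, is whether an amine or a nitrile in place of the bromine on the phenyl ring would give steps that differ between the cores in the same way.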